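Urea to methoxybenzamide on a trimethoxyphenyl amide scaffold

The source may hold more compounds than are shown below. What is called first, only, known or untested is meant among the compounds shown, and "the series" means these compounds.

Compound 1, `COc1cc(N(C)C(=O)c2ccccc2)cc(OC)c1OC`: in a functional assay on ONS-76 cells (Homo sapiens) for cytotoxicity, read by MTT assay, with a stated time of 72 h (on this read-out lower numbers stand for stronger inhibition and higher numbers for weaker inhibition), compound 1 gives >= 125000 nM, a limit of the assay.
Compound 2, `COc1cc(N(C)C(=O)c2cccc(F)c2)cc(OC)c1OC`: in this assay compound 2 gives >= 125000 nM, also a limit.
Compound 3, `COc1cc(N(C)C(=O)N(C)c2ccccc2)cc(OC)c1OC`: in this assay compound 3 gives "not determined" (no result reported), so no result is reported for it.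

Compound 3 stands nowhere on the numbers: its activity in this assay was not determined, so it carries no value of its own. Among the compounds with values here, the only measured step, a step that the two limits leave unreadable from compound 1 to compound 2, is of unreadable size, since both ends sit at the limit of >= 125000 nM in this assay, at which 2 of the 3 values shown sit. Of the three values shown, two are therefore limits rather than numbers, and the third is missing.

Compound 4 is `COc1ccc(C(=O)N(C)c2cc(OC)c(OC)c(OC)c2)cc1`. It differs from compound 3 by 4-methoxyphenyl in place of methyl(phenyl)amino on a carbonyl carbon. The change turns a urea into a benzamide, making compound 4 a close relative of compound 1 and compound 2, which both sit at the limit. Within the data shown here, no measured step bears directly on this change, and none shows a readable size in either direction, so there is no basis to expect a step beyond the scatter for compound 4 in this assay.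

Against that background, compound 4 is expected to give roughly 50000 nM in this assay, with an estimated range of 2000 nM to 125000 nM.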

Compound 4, half-maximal inhibitory concentration: >= 125000 nM
Compound 4: a limit, no number; the forecaster's own chance of this, stated with the estimate: 45%; at least 2.5-fold (0.39 log units) between middle value and limit.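

In this assay compound 4 gives >= 125000 nM, a limit and not a number. No step from compound 1 or compound 2 to compound 4 can be read, because all three compounds sit at the same limit: the limit of >= 125000 nM in this assay, at which 3 of the 4 values shown sit.

The compounds shown leave open which group on the carbonyl carbon, if any, would give a readable number in this assay.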